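This account rests on a few compounds, and the source may have more. Where it says the series, first, only, none or still open, it means among the compounds named here.

Measured compounds in a functional assay on cells (Endothelial cell, Bos taurus) for antiproliferative activity; on this read-out lower numbers stand for stronger inhibition and higher numbers for weaker inhibition:
compound 1 `COc1ccc(/C=C(/F)c2cc(OC)c(OC)c(OC)c2)cc1N` gives 2000 nM
compound 2 `COc1ccc(/C=C(\F)c2cc(OC)c(OC)c(OC)c2)cc1N` gives 86000 nM
compound 3 `COc1cc(/C=C/c2cc(O)c3ccoc3c2)cc(OC)c1OC` gives 27000 nM

Compound 1 stands lowest of the three numbers in this assay. Compound 3 sits well above it, and the values of the two are all that can be said of that pair, since they differ in more than one place. Among the compounds with values here, the one measured step in the set is a 43-fold higher number from compound 1 to compound 2 (1.63 log units; beyond the scatter): a large loss that is tied to configuration alone because of the fact that compounds 1 and 2 differ only in the configuration as drawn.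

Compound 4 `COc1ccc(/C=C(/F)c2cc(OC)c(OC)c(OC)c2)cc1[N+](=O)[O-]` keeps the configuration of compound 1 and changes a single group: nitro in place of amino on an aromatic carbon. Within the data shown here, no measured step in this assay concerns a swap of this kind; the configuration step from compound 1 to compound 2 does not bear on it. The expectation for compound 4 therefore rests on the value of compound 1 alone, with a modest move upward allowed for the loss of the amino group and the wide range that an unsupported change carries. The step of a 3.0-fold higher number from compound 1 to compound 4 (0.48 log units; beyond the scatter) is the estimated shift. Compound 4 is expected to give 6000 nM in this assay, within a range of 1500 nM to 30000 nM.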

Compound 4, half-maximal inhibitory concentration: 38400 nM
Compound 4: middle estimate off by 6.4-fold (0.81 log units), on the low side; measured number above the stated range.
By their numbers in this assay, from the lowest: compound 1; then compounds 3 and 4 (each within the scatter of the next); then compound 2.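

Nitro in place of amino on an aromatic carbon, ortho to a methoxy group, is a large change in this assay: a 19-fold higher number from compound 1 to compound 4 (1.28 log units; beyond the scatter). Until now, the only single-place change in the series was the configuration of the double bond, a 43-fold higher number from compound 1 to compound 2 (1.63 log units; beyond the scatter); this second step shows that, among the compounds shown, changing this ring position while keeping the configuration of compound 1 also moves the number well beyond the scatter. Nothing measured here accounts for the size of the step from amino to nitro.

The compounds shown leave open whether the step follows from the loss of amino or from the entry of nitro: a hydroxyl group, an acetamido group or a plain hydrogen at this place would help separate the two. They also leave open whether the swap from amino to nitro carries a step of similar size in the double-bond configuration of compound 2, and whether a methylamino group would stay close to compound 1 in this assay.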